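The compounds below may be only part of what the source reports. "The series", "measured", "known", "first", "only" and "open" are said of these compounds alone.

Working notes on the series, continued at compound 3. Compound 1 `CCCCCCc1c(F)c(N)c2c(=O)cc(-c3ccc(N)c(F)c3)oc2c1F` gives 21000 nM in a functional assay on HeLa cells (Homo sapiens) for cytotoxicity, read by neutral red uptake, with a stated time of 3 days (a higher number here means a weaker inhibitor, a lower number a stronger inhibitor), and compound 2 `[N-]=[N+]=Nc1c(F)c(N)c2c(=O)cc(-c3ccc(N)c(F)c3)oc2c1F` gives 1200 nM. Compound 3 `CN(C)c1c(F)c(N)c2c(=O)cc(-c3ccc(N)c(F)c3)oc2c1F` sits at the limit of this assay, > 100000 nM, which is a limit and not a number (the limit of > 100000 nM in this assay, at which 1 of the 3 values shown sits). The measured steps are an 18-fold lower number from compound 1 to compound 2 (1.24 log units; beyond the scatter), an at least 4.7-fold higher number from compound 1 to compound 3 (0.67 log units; beyond the scatter) and an at least 83-fold higher number from compound 2 to compound 3 (1.92 log units; beyond the scatter). Compound 4 `Nc1ccc(-c2cc(=O)c3c(N)c(F)c(C(=O)O)c(F)c3o2)cc1F` differs from compound 3 in one place: carboxy in place of dimethylamino on an aromatic carbon. For the measured compounds named here, no measured step puts a carboxy group at this position, so none bears on it directly; the measured steps show only that the hexyl and azido groups both give lower numbers than the dimethylamino group. A step downward from the limit is therefore expected, an at least 2.0-fold lower number from compound 3 to compound 4 (0.30 log units; that floor lies within the scatter), with much uncertainty. Compound 4 is estimated at 50000 nM, between 10000 nM and 200000 nM.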

Compound 4, half-maximal inhibitory concentration: > 100000 nM
Compound 4 was reported as a limit; the forecaster's own chance of this, stated with the estimate: 35%; middle value at least 2.0-fold (0.30 log units) away from the limit.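

Compound 4, like compound 3, is reported only as a limit and not as a number: the limit of > 100000 nM in this assay, at which 2 of the 4 values shown sit. Carboxy in place of azido gives an at least 83-fold higher number from compound 2 to compound 4 (1.92 log units; beyond the scatter), and carboxy in place of hexyl gives an at least 4.7-fold higher number from compound 1 to compound 4 (0.67 log units; beyond the scatter), so a second group at this position now falls short of both measured groups. The step between compound 3 and compound 4 cannot be read, as both values are limits.

As far as these compounds go, whether carboxy and dimethylamino differ at all remains open. So does what a primary amine, a methyl ester or a shorter alkyl chain would give at this position.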